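The source may report more compounds than this note shows. Statements on the series, on what has been measured and on what is new or still open speak of the compounds shown alone.

Measured compounds:
compound 1 `Cn1c(-c2ccc(NC(=O)CSc3nc4ccccc4o3)cc2)nc(-c2ccccc2)c1-c1ccccc1`: 24.8%
compound 2 `Cn1c(-c2ccc(NC(=O)CSc3nc4ccccc4s3)cc2)nc(-c2ccccc2)c1-c1ccccc1`: 9.8%

Both compounds were tested in a functional assay on HT-29 cells (Homo sapiens) for cytotoxicity, read by MTT assay, with a stated time of 24 h, tested at 0.64 ug/mL; a lower number here means a weaker effect, a higher number a stronger effect of the compound at the concentration tested. In this assay compound 1 gives 24.8%, and compound 2 gives 9.8%. Compound 2 therefore has the lowest of the two numbers; its nearest neighbour is compound 1, whose number lies higher by more than the scatter. For the measured compounds named here, the only step measured so far is a number 15 percentage points lower from compound 1 to compound 2 (beyond the scatter).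

Compound 3 `Cn1c(-c2ccc(NC(=O)CSC3=NCCS3)cc2)nc(-c2ccccc2)c1-c1ccccc1` has not yet been measured in this assay. It differs from compound 2 in one place: a group of 5 heavy atoms (3 carbon, 1 nitrogen, 1 sulfur; one five-membered non-aromatic ring with 2 hetero atoms) in place of a group of 9 heavy atoms (7 carbon, 1 nitrogen, 1 sulfur; one five-membered aromatic ring with 2 hetero atoms, one six-membered aromatic ring of carbon only), on a sulfur. Going by the values given here, no measured step covers this kind of change. Among the compounds with values here, the single known step, from compound 1 to compound 2, concerned a different exchange on a sulfur and was modest in size, so it offers no direct guide to swapping an aromatic group for a five-membered non-aromatic ring. The number for compound 3 is therefore expected to stay close to that of compound 2, with an estimated change of a number 3.2 percentage points higher from compound 2 to compound 3 (within the scatter) that does not clearly exceed the scatter in either direction. Compound 3 is estimated at 13%, with a range from 2% to 28%.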

Compound 3, a percentage reported as activity, at one concentration (the size of the read-out at that concentration, not a potency): 16.8%
Beside the measured number, compound 3's estimate is 3.8 percentage points below it; measured number inside the range.
By their numbers in this assay, from the lowest: compounds 2, 3 and 1 (each within the scatter of the next, the first and the last beyond it).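

Swapping the fused aromatic groups on the sulfur for a non-aromatic five-membered ring of 5 heavy atoms gives, in this assay, a number 7 percentage points higher from compound 2 to compound 3 (within the scatter) and a number 8 percentage points lower from compound 1 to compound 3 (within the scatter). Neither step clears the scatter, even though the two aromatic groups differ from each other by more than the scatter, so the new ring cannot be told apart from either of them at this position. Among these compounds, then, neither an aromatic ring nor a six-membered ring of carbon on this sulfur is needed for a number in this range, and no independent data are available to explain this result.

These are single read-outs at one concentration, so they show the size of the effect at that concentration, not potency, and the small gaps leave the order of compound 3 relative to the other two unsettled. From the compounds shown here alone, whether this sulfur tolerates quite different groups remains open, for example a simple amine such as morpholine, a carboxylic acid, or a longer saturated chain in place of the ring.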